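The source may report more compounds than this note shows. Statements on the series, on what has been measured and on what is new or still open speak of the compounds shown alone.

Working notes on the series. Compound 1 `C#Cc1cccc(Nc2nc(Nc3cccc(Cl)c3)nc3cc(OC)c(OC)cc23)c1` carries a chloro-substituted anilino group on the shared core; in a functional assay on SK-HEP1 cells (Homo sapiens) for inhibition, read by MTT assay, with a stated time of 48 h (a lower number here means a stronger inhibitor, a higher number a weaker inhibitor), compound 1 gives 7100 nM. Compound 2 `C#Cc1cccc(Nc2nc(Nc3cc(C)ccc3F)nc3cc(OC)c(OC)cc23)c1` differs in one place, with 2-fluoro-5-methylphenyl in place of 3-chlorophenyl on a nitrogen on an aromatic ring; in this assay compound 2 gives 4500 nM. The step of a 1.6-fold lower number from compound 1 to compound 2 (0.20 log units; within the scatter) lies within the scatter, so compound 1 stands at the highest of the two numbers recorded without being separable from compound 2.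

Compound 3 `C#Cc1cccc(Nc2nc(Nc3cccc(Oc4ccc(C#N)cc4)c3)nc3cc(OC)c(OC)cc23)c1` has not yet been measured. It differs from compound 1 in 4-cyanophenoxy in place of chloro on an aromatic carbon, the change sitting on the same aryl ring that was reworked between compound 1 and compound 2. Going by the values given here, no measured step covers this kind of change; the only step available, a 1.6-fold lower number from compound 1 to compound 2 (0.20 log units; within the scatter), stayed within the scatter while altering that ring in a different way. The expectation in this assay is therefore no step beyond the scatter, with a wide range to cover the larger group entering. Compound 3 is estimated at 5500 nM, within 1500 nM to 20000 nM. The expected step of a 1.3-fold lower number from compound 1 to compound 3 (0.11 log units; within the scatter) is thus within the scatter.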

Compound 3, half-maximal inhibitory concentration: 3900 nM
Compound 3: middle estimate off by 1.4-fold (0.15 log units), on the high side; low and high end bracket the measured number.
By their numbers in this assay, from the lowest: compounds 3, 2 and 1 (each within the scatter of the next).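

On this aromatic carbon, meta to a large group, 4-cyanophenoxy replaces chloro, bringing 9 heavy atoms in place of 1 heavy atom, a further six-membered aromatic ring of carbon only and a nitrile, and this assay gives a 1.8-fold lower number from compound 1 to compound 3 (0.26 log units; within the scatter). Compound 1 and compound 2 showed only an exchange of small substituents on this aryl ring, whereas compound 3 shows that a far larger group at this position still does not separate from chloro in this assay. Nothing measured on these compounds bears on why the number stays at this level.

Still open, going by these compounds, is whether any group on this carbon can move the number beyond the scatter, with an amine, a carboxylic acid or a longer alkyl chain as different kinds of group to set against chloro and 4-cyanophenoxy. Also open, on these data alone, is what the nitrile itself contributes, for which an unsubstituted phenoxy group on the same carbon would give the direct one-place comparison with compound 3.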